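This account rests on a few compounds, and the source may have more. Where it says the series, first, only, none or still open, it means among the compounds named here.

Measured so far in a functional assay on HeLa cells (Homo sapiens) for antiproliferative activity, read by MTT assay, with a stated time of 48 h; on this read-out higher numbers stand for weaker inhibition and lower numbers for stronger inhibition:
compound 1 `C#Cc1cccc(Nc2ncnc3cc(NC(=O)/C=C/c4ccccc4)sc23)c1`: 20500 nM
compound 2 `N#Cc1cccc(Nc2ncnc3cc(NC(=O)/C=C/c4ccccc4)sc23)c1`: 7220 nM
compound 3 `O=C(/C=C/c1ccccc1)Nc1cc2c(Nc3ccc(Cl)c(Cl)c3)ncnc2s1`: 430 nM

Compound 2 has the second highest of the three numbers, lying between the other two compounds. The next compound is the unmeasured compound 4 `O=C(/C=C/c1ccccc1)Nc1cc2ncnc(Nc3cc(Cl)cc(Cl)c3)c2s1`. It keeps the core of compound 2 and has 3,5-dichlorophenyl in place of 3-cyanophenyl on a nitrogen on an aromatic ring.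

For the measured compounds named here, only one measured step bears directly on this aryl group: a 2.8-fold lower number from compound 1 to compound 2 (0.45 log units; beyond the scatter). That step is modest but beyond the scatter, and it involves no chlorine, so it gives little guidance on size. Compound 3 also carries a dichlorophenyl group and gives 430 nM. However, its core and chlorine placement differ from those of compound 4, and no single measured step isolates either difference. With that value from compound 3 as the closest available guide, a clear move to a lower number is expected in this assay, though with considerable uncertainty. The expected change is a 4.0-fold lower number from compound 2 to compound 4 (0.60 log units; beyond the scatter). Compound 4 is estimated at 1800 nM, with an expected range of 400 nM to 8000 nM.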

Compound 4, half-maximal inhibitory concentration: 3210 nM
Compound 4: middle estimate off by 1.8-fold (0.25 log units), on the low side; low and high end bracket the measured number.
By their numbers in this assay, from the lowest: compound 3; then compound 4; then compound 2; then compound 1.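

Working notes on the aryl group on the nitrogen: in this assay, 3,5-dichlorophenyl in place of 3-cyanophenyl gives a 2.2-fold lower number from compound 2 to compound 4 (0.35 log units; beyond the scatter) and, in place of 3-ethynylphenyl on the same core, gives a 6.4-fold lower number from compound 1 to compound 4 (0.81 log units; beyond the scatter), so both singly substituted rings shown are improved on by this doubly chlorinated ring. Until now this position had shown only the exchange of ethynyl for cyano; the new steps show that a lower number does not depend on the nitrile, since the entering group counts 0 hydrogen-bond acceptors against 1 for 3-cyanophenyl, at an equal count of 8 heavy atoms. Nothing measured on hand accounts for either step.

The two chlorines are not separated here, so 3-chlorophenyl, 3,5-difluorophenyl and 3,5-dimethylphenyl would show whether the number of substituents or the chlorine itself carries the step. Compound 3 differs from compound 4 in more than one place, so the contributions of chlorine placement and of the core remain unresolved.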